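Hydroxyalkyl chain length on the sulfonyl piperidine series

A few compounds are considered here, and "the series" means these few. Any claim that something is new, unique, unknown or untested is made for them only; others in the source may bear on it.

In a functional assay on HEK293 cells for agonist activity at Glucose-dependent insulinotropic receptor (Homo sapiens), read by cAMP accumulation, with a stated time of 60 min (a higher number here means that more compound is needed for the effect, a lower number that less compound is needed), compound 1 `CCCc1cnc(N2CCC(C3Cc4cc(C5=CCN(S(=O)(=O)CCCO)CC5)cc(F)c4O3)CC2)nc1` gives 122 nM. Compound 2 `CCCc1cnc(N2CCC(C3Cc4cc(C5=CCN(S(=O)(=O)CCCCO)CC5)cc(F)c4O3)CC2)nc1` carries hydroxymethyl in place of hydroxy on a saturated chain carbon, three bonds along the chain from a sulfonyl sulfur and in this assay compound 2 gives 60 nM; the step of a 2.0-fold lower number from compound 1 to compound 2 (0.31 log units; beyond the scatter). Compound 3 `CCCc1cnc(N2CCC(C3(C)Cc4cc(C5=CCN(S(=O)(=O)CCCO)CC5)ccc4O3)CC2)nc1` is built on a different core; how the core of compound 3 differs from the core of compound 1 is not broken down here. In this assay compound 3 gives 78 nM, which lies within the scatter of compound 2 and of compound 1. Compound 4 `CCCc1cnc(N2CCC(C3(C)Cc4cc(C5=CCN(S(=O)(=O)CCCCO)CC5)ccc4O3)CC2)nc1` is not yet measured; it differs from compound 3 by hydroxymethyl in place of hydroxy on a saturated chain carbon, three bonds along the chain from a sulfonyl sulfur, the same change as from compound 1 to compound 2. Among the compounds with values here, a step of similar size is expected, a 1.9-fold lower number from compound 3 to compound 4 (0.27 log units; within the scatter), resting on the single prior instance a 2.0-fold lower number from compound 1 to compound 2 (0.31 log units; beyond the scatter). Compound 4 is therefore estimated at 42 nM, with a range from 22 nM to 80 nM.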

Compound 4, half-maximal effective concentration: 28 nM
Beside the measured number, compound 4's estimate is 1.5-fold (0.18 log units) above it; the range from low to high includes it.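

In this assay the same lengthening recurs on the second core, a 2.8-fold lower number from compound 3 to compound 4 (0.44 log units; beyond the scatter), and its size agrees with the earlier step: the same change on two cores in this assay, a 2.0-fold lower number (0.31 log units; beyond the scatter) from compound 1 to compound 2 and a 2.8-fold lower number (0.44 log units; beyond the scatter) from compound 3 to compound 4, 1.4-fold (0.14 log units) apart, within the scatter of two such steps. The change from 3-hydroxypropyl to 4-hydroxybutyl on the sulfonyl therefore carries over between these two cores, with no difference in size that can be read. Within the data shown here, with only one pair on each core, this does not show that the change would carry to any further core, nor why the number moves.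

Still open, going by these compounds, is whether a longer chain than 4-hydroxybutyl would lower the number further. Also open, on these data alone, is how an amine or a carboxylic acid in place of the hydroxy would read.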